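Sulfonyl substituent exchange on an inactive quinolone series

The source may report more compounds than this note shows. Statements on the series, on what has been measured and on what is new or still open speak of the compounds shown alone.

Compound 1 `COc1ccc(-c2[nH]c3cc(OC)cc(OC)c3c(=O)c2I)cc1` in an ADME assay on BJ cells (Homo sapiens) for antiproliferative activity, with a stated time of 72 h (a higher number here means that more compound is needed for the effect, a lower number that less compound is needed), gives a limit, > 86200 nM. Compound 2 `COc1ccc(-c2cc(=O)c3c(OC)cc(OC)cc3n2S(=O)(=O)c2ccc([N+](=O)[O-])cc2)cc1` gives a limit, > 29300 nM. Compound 3 `COc1ccc(-c2cc(=O)c3c(OC)cc(OC)cc3n2S(=O)(=O)c2c(C(C)C)cc(C(C)C)cc2C(C)C)cc1` gives a limit, > 341000 nM.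

Compound 2 thus stands at a limit of this assay, (the limit of > 29300 nM in this assay, at which 1 of the 3 values shown sits), and the other two values are limits as well, so no order among the three compounds can be read. Compound 4 `COc1ccc(-c2cc(=O)c3c(OC)cc(OC)cc3n2S(=O)(=O)c2ccc(Br)s2)cc1` differs from compound 2 in one place: 5-bromothiophen-2-yl in place of 4-nitrophenyl on a sulfonyl sulfur. Going by the values given here, with no measured step among the three compounds to guide the size or direction, the author expects no change beyond the scatter a step that the limit leaves unreadable from compound 2 to compound 4 for the step to compound 4. Compound 4 is therefore estimated at 60000 nM, with a range from 20000 nM to 200000 nM, most likely reported again as a limit.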

Compound 4, half-maximal effective concentration: > 48200 nM
Compound 4: no number, only a limit; the forecaster's own chance of this, stated with the estimate: 85%; the middle value lies beyond the limit too.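

Compound 2 and compound 4 both give only a limit in this assay, so the step between them cannot be read. The compounds shown leave open whether any sulfonyl substituent on the shared core gives a measurable value.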